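This account rests on a few compounds, and the source may have more. Where it says the series, first, only, none or still open, it means among the compounds named here.

Measured compounds:
Compound 1, `CNC(=O)/C=C/c1ccc2noc(-c3ccccc3)c2c1`, gives 42600 nM in an assay for inhibition of inositol hexakisphosphate kinase 3 (Homo sapiens), read by colorimetric assay, coupled enzyme assay and malachite green, with a stated time of 120 min, in the presence of a further agent that is not named here; a lower number here means a stronger inhibitor, a higher number a weaker inhibitor.
Compound 2, `Cc1ccc(-c2onc3ccc(/C=C/C(=O)O)cc23)cc1`, gives 11500 nM in this assay.

Among the compounds with values here, of the two numbers so far, compound 2 holds the lower one, and its gap to compound 1 is beyond the scatter of repeated measurements. Within the data shown here, the two compounds differ in more than one place, so the data show only what their two values are and carry no single step between them.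

Compound 3, `O=C(O)/C=C/c1ccc2noc(-c3ccc(-c4ccccc4)cc3)c2c1`, has not yet been measured. Set against compound 2, the change is phenyl in place of methyl on an aromatic carbon, para to a large group. Among the measured compounds shown here, nothing among the measured compounds isolates such an exchange, so no step of known size is available to lean on.

With the shared core kept and only a group on the outer ring exchanged, the account expects the step of a 1.4-fold lower number from compound 2 to compound 3 (0.16 log units; within the scatter) to fall close to or modestly below the value of compound 2, rather than a large shift in either direction. For compound 3 the estimate in this assay is 8000 nM, with a range from 2500 nM to 25000 nM.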

Compound 3, half-maximal inhibitory concentration: 200 nM
The estimate for compound 3 lay 40-fold (1.60 log units) above the measured number, outside the stated range (below it).
By their numbers in this assay, from the lowest: compound 3; then compound 2; then compound 1.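

The exchange of methyl for phenyl, on an aromatic carbon of a six-membered aromatic ring of carbon only and para to a large group, gives a 58-fold lower number from compound 2 to compound 3 (1.76 log units; beyond the scatter) in this assay. Within the data shown here, this is the first single step, and it shows that the number in this assay responds strongly to what stands at this position. The entering phenyl brings no hydrogen-bond donors, no hydrogen-bond acceptors and no net charge, so a step of this size occurs here without any change in those counts, and nothing measured on these compounds bears on why the step is so large.

Going by these compounds, it remains open whether the gain belongs to phenyl itself or would also come with other groups at this position, such as a cyclohexyl, a benzyl, a methoxy or a phenyl ring carrying an amine. On these data alone, it is equally open whether the same exchange would give a step of similar size with an ester or an amide in place of the carboxylic acid.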